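The source may hold more compounds than are shown below. What is called first, only, known or untested is meant among the compounds shown, and "the series" means these compounds.

Working notes on a small series sharing one core, followed in a functional assay on A375P cells (Homo sapiens) for inhibition, read by MTT assay, with a stated time of 24 h; a lower number here means a stronger inhibitor of growth, a higher number a weaker inhibitor of growth. Compound 2 `COc1ccc(Cn2ncc3c2NC(=O)CC(c2cccc(NC(=O)Nc4ccc(Cl)cc4)c2)=N3)cc1` gives 640 nM, the lower of the two numerical results, while compound 1 `O=C1CC(c2ccc(NC(=O)Nc3cccc(Cl)c3)cc2)=Nc2cnn(Cc3ccccc3)c2N1` gives 2070 nM, a gap beyond the scatter. These two compounds differ in more than one place, so that gap is not read as the effect of a single change. Compound 3 `O=C1CC(c2cccc(NC(=O)Nc3ccc(Cl)cc3)c2)=Nc2cn[nH]c2N1` returns only a limit, > 30000 nM.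

The next step leads to compound 4 `COc1ccc(Cn2ncc3c2NC(=O)CC(c2cccc(NC(=O)Nc4ccc(C(F)(F)F)cc4)c2)=N3)cc1`, with trifluoromethyl in place of chloro on an aromatic carbon, para to a large group: trifluoromethyl in place of chloro on an aromatic carbon. Among the compounds with values here, the only measured single-place step, an at least 46-fold higher number from compound 2 to compound 3 (1.67 log units; beyond the scatter), is large, but it is hydrogen in place of 4-methoxybenzyl on an aromatic nitrogen, and compound 4 keeps the 4-methoxybenzyl group. Within the data shown here, that step therefore gives no size for the present change, and no measured step touches the chloro position. With compound 2 at 640 nM as the anchor, no step beyond the scatter is expected in this assay. The estimated 1.1-fold lower number from compound 2 to compound 4 (0.04 log units; within the scatter) is accordingly small, with no firm direction. For compound 4 the expected value is 580 nM, with an estimated range of 210 nM to 1600 nM.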

Compound 4, concentration for 50% growth inhibition: 770 nM
Beside the measured number, compound 4's estimate is 1.3-fold (0.12 log units) below it, and the stated range covers the measured number.
By their numbers in this assay, from the lowest: compounds 2 and 4 (each within the scatter of the next); then compound 1. At a limit, above all of these: compound 3.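

In this assay the position on the six-membered aromatic ring of carbon only, para to a large group, now has its first measured single-place step: a 1.2-fold higher number from compound 2 to compound 4 (0.08 log units; within the scatter) on placing trifluoromethyl where chloro stood. With the 4-methoxybenzyl group and the rest of compound 2 held constant, the two substituents cannot be told apart by this read-out, and the position accepts the change from 4-chlorophenyl to 4-(trifluoromethyl)phenyl without a step beyond the scatter. Nothing measured bears on why these two groups give results within the scatter of each other.

Only chloro and trifluoromethyl are shown at this position, so it remains open whether an amine, a carboxylic acid or a longer chain there would leave the number within the scatter or move it beyond. Also open, going by these compounds, is the same exchange on compound 3, which carries hydrogen on the aromatic nitrogen and whose > 30000 nM is a limit and not a number.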